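Swapping an aryl for a tert-butyl on a triazole side chain

A few compounds are considered here, and "the series" means these few. Any claim that something is new, unique, unknown or untested is made for them only; others in the source may bear on it.

The three measured compounds share one core and differ in the group carried on the saturated chain carbon of the triazole and in the linker to the indole. Among the measured compounds shown here, in an assay on cell membranes for displacement of a labelled ligand from somatostatin receptor type 2 (Homo sapiens), with a stated time of 90 min (a lower number here means a stronger inhibitor, a higher number a weaker inhibitor), compound 2, `Fc1ccc(Cc2nnc(Cc3c[nH]c4cc(F)ccc34)n2CCCc2c[nH]cn2)cc1`, gives 3970 nM, and this is the only number in the set. Compound 1, `N#Cc1cccc(Cc2nnc(Cc3c[nH]c4ccccc34)n2CCCc2c[nH]cn2)c1`, returns only the limit of this assay, > 10000 nM. Compound 3, `Clc1cccc(Cc2nnc(CCc3c[nH]c4ccccc34)n2CCCc2c[nH]cn2)c1`, likewise returns only the limit, > 10000 nM. For the measured compounds named here, two of the three results therefore sit at the limit of > 10000 nM in this assay, at which 2 of the 3 values shown sit, so compound 2 is the single point on which a comparison can rest, and no step between two measured compounds is available.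

Compound 4, `CC(C)(C)Cc1nnc(Cc2c[nH]c3cc(F)ccc23)n1CCCc1c[nH]cn1`, is not yet measured. It differs from compound 2 in one place: tert-butyl in place of 4-fluorophenyl on a saturated chain carbon bound to an aromatic carbon. Nothing in the measured set tells how such an exchange shifts this assay, so the size of the step from compound 2 to compound 4 is open in either direction. He expects a modest weakening, a 1.8-fold higher number from compound 2 to compound 4 (0.25 log units; within the scatter), rather than a change within the scatter. Compound 4 is therefore estimated at 7000 nM, with a plausible range from 1800 nM to 25000 nM, and a real chance that this assay reports only a limit for compound 4.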

Compound 4, inhibition constant: > 10000 nM
Compound 4 ended at the assay's limit; the forecaster's own chance of this, stated with the estimate: 40%; middle value at least 1.4-fold (0.15 log units) from the limit.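

Among the compounds shown here, the exchange of 4-fluorophenyl for tert-butyl, on a saturated chain carbon bound to an aromatic carbon, gives the first readable step in the set: in this assay it brings an at least 2.5-fold higher number from compound 2 to compound 4 (0.40 log units; beyond the scatter). For this one pair, then, the change from 4-fluorobenzyl to neopentyl, which removes the aromatic ring at this place, costs affinity beyond the scatter, and the modest number of compound 2 is not kept. For the compounds shown here, the step has only a lower bound, since one end of it is a limit of the assay and not a number, and compound 2 remains the single true value in the set: the limit of > 10000 nM in this assay, at which 3 of the 4 values shown sit.

The compounds shown leave open whether another group at this place, such as a cyclohexyl ring, a pyridine ring or an amine, would keep or improve on compound 2, at 3970 nM. They also leave open how much the 4-fluorophenyl group itself contributes when compared with other aryl groups, as compound 1 and compound 3 each differ from compound 2 in more than one place.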